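Pyridine exchange on the compound 2 scaffold

The source may hold more compounds than are shown below. What is called first, only, known or untested is meant among the compounds shown, and "the series" means these compounds.

Compound 1 `NS(=O)(=O)c1ccc(Nc2nc(-c3cccc(-c4ccccc4)c3)c3nc[nH]c3n2)cc1` gives > 100000 nM in a functional assay on A2058 cells (Homo sapiens) for antiproliferative activity, read by luminescence and CellTiter-Glo, with a stated time of 96 h (on this read-out lower numbers stand for stronger inhibition and higher numbers for weaker inhibition), as a limit, not a number.
Compound 2 `O=C(Nc1ccc(F)cc1)c1n[nH]cc1NC(=O)c1c(F)ccc(-c2ccncc2)c1F` gives 2940 nM in this assay as a measured number.

Within the data shown here, compound 2 holds the only number so far, and the one other value is a limit. Its standing therefore rests on a single reading, and no series trend can be drawn. Compound 3 `Nc1ccc(-c2ccc(F)c(C(=O)Nc3c[nH]nc3C(=O)Nc3ccc(F)cc3)c2F)cn1` is the next to be read. It has 6-aminopyridin-3-yl in place of pyridin-4-yl on an aromatic carbon and otherwise keeps the structure of compound 2. Among the measured compounds shown here, no measured pair tests this exchange, so the expectation in this assay is only a modest gain in inhibition, with a wide margin that includes no change beyond the scatter. The expected step is a 2.5-fold lower number from compound 2 to compound 3 (0.39 log units; beyond the scatter) as a rough estimate. For compound 3 the estimated value is 1200 nM within an expected range of 200 nM to 6000 nM.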

Compound 3, half-maximal inhibitory concentration: 8540 nM
For compound 3 the middle estimate is 7.1-fold (0.85 log units) below the measured one; the whole stated range lies below it.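

Among these compounds, this is the first measured exchange: on this aromatic carbon, 6-aminopyridin-3-yl in place of pyridin-4-yl gives a 2.9-fold higher number from compound 2 to compound 3 (0.46 log units; beyond the scatter) in this assay. The position is therefore sensitive to the group it carries, and here the exchange weakens inhibition, though the step is modest. Compound 3 still gives a measured number, 8540 nM, so inhibition is weakened but not lost with this group in place.

As far as these compounds go, the pair changes the pyridine attachment and adds an amino group in one step, so the two changes cannot be separated, and it remains open how plain pyridin-3-yl or a morpholine on this carbon would read. Among the compounds shown here, nothing measured so far bears on the reason for this step.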